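The source may report more compounds than this note shows. Statements on the series, on what has been measured and on what is new or still open speak of the compounds shown alone.

Measured so far:
- compound 1 `O=C(NCc1ccc(S(=O)(=O)c2cncc(C(F)(F)F)c2)cc1)N1Cc2ccncc2C1`: 10 nM in a functional assay on A2780 cells (Homo sapiens) for cytotoxicity, read by sulforhodamine B assay, with a stated time of 72 h; on this read-out lower numbers stand for stronger inhibition and higher numbers for weaker inhibition
- compound 2 `CC(C)n1cc(S(=O)(=O)c2ccc(CNC(=O)N3Cc4ccncc4C3)cc2)cn1`: 11 nM in this assay

Among the compounds with values here, compound 2 holds the higher of the two numbers, with compound 1 nearest; the single step, a 1.1-fold higher number from compound 1 to compound 2 (0.04 log units; within the scatter), falls within the scatter, so the two are not separated. Compound 3 `O=C(NCc1ccc(S(=O)(=O)N2CCC(N3CCCC3)CC2)cc1)N1Cc2ccncc2C1` differs from compound 2 in one place: 4-(pyrrolidin-1-yl)piperidin-1-yl in place of 1-isopropyl-1H-pyrazol-4-yl on a sulfonyl sulfur. Within the data shown here, the only measured step at the sulfonyl sulfur, a 1.1-fold higher number from compound 1 to compound 2 (0.04 log units; within the scatter), exchanges one aromatic group for another and leaves the number essentially unchanged; it bears on compound 3 only loosely, since the entering group is non-aromatic and brings two saturated rings, a change of a different kind that no measured pair covers. The expectation is therefore a modest rise in number, with wide uncertainty. Compound 3 is estimated at 30 nM, range 8 nM to 150 nM, which would be a step of a 2.7-fold higher number from compound 2 to compound 3 (0.44 log units; beyond the scatter).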

Compound 3, half-maximal inhibitory concentration: 5.6 nM
Estimate against measurement, compound 3: 5.4-fold (0.73 log units) above, and the stated range ends above it.
By their numbers in this assay, from the lowest: compounds 3, 1 and 2 (each within the scatter of the next).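

At the sulfonyl sulfur, a non-aromatic group with two saturated rings now stands alongside the two aromatic groups in this assay, and neither the step of a 2.0-fold lower number from compound 2 to compound 3 (0.29 log units; within the scatter) nor that of a 1.8-fold lower number from compound 1 to compound 3 (0.25 log units; within the scatter) separates it from them. Among these three compounds, then, an aromatic ring on the sulfonyl sulfur is not required to keep the number in this range, and 4-(pyrrolidin-1-yl)piperidin-1-yl is accepted there without a readable change. Nothing at hand accounts for this result.

Open, on these data alone, is whether an open-chain amine such as dimethylamino, or a carboxylic acid on the piperidine ring, would keep the number in the same range. Also open, as far as these compounds go, is whether any group on this sulfur can produce a step beyond the scatter.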